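This account rests on a few compounds, and the source may have more. Where it says the series, first, only, none or still open, it means among the compounds named here.

Compound 1 `[O-]/[N+](=C\c1cn(-c2ccc(F)cc2)nn1)c1ccccc1`: > 20000 nM, a limit
Compound 2 `[O-]/[N+](=C\c1cn(-c2ccc(F)cc2)nn1)Cc1ccccc1`: 9700 nM
Compound 3 `CC(C)(C)/[N+]([O-])=C/c1cn(-c2ccccc2)nn1`: > 20000 nM, a limit

In a functional assay on THP-1 cells (Homo sapiens) for inhibition, read by ELISA, with stated times of 2 h and 48 h (a lower number here means a stronger inhibitor, a higher number a weaker inhibitor), compound 3 gives > 20000 nM, which is a limit and not a number. Compound 3 therefore sits at the limit of > 20000 nM in this assay, at which 2 of the 3 values shown sit. Compound 4 `CC(C)(C)/[N+]([O-])=C/c1cn(-c2ccc(F)cc2)nn1` differs from compound 3 by fluoro in place of hydrogen on an aromatic carbon. Among the measured compounds shown here, no measured step covers this change. For the measured compounds named here, the only measured step, an at least 2.0-fold lower number from compound 1 to compound 2 (0.31 log units; beyond the scatter), is benzyl in place of phenyl on a double-bonded nitrogen, so it bears on this change only loosely. A modest step towards a lower number, or none beyond the scatter, is therefore expected. The expected change is an at least 1.2-fold lower number from compound 3 to compound 4 (0.09 log units; that floor lies within the scatter). The estimate for compound 4 is 16000 nM, with an expected range from 6000 nM to 30000 nM.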

Compound 4, half-maximal inhibitory concentration: 14000 nM
For compound 4 the middle estimate is 1.1-fold (0.06 log units) above the measured one; the range from low to high includes it.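

In this assay, fluoro in place of hydrogen on an aromatic carbon, para to a large group, gives an at least 1.4-fold lower number from compound 3 to compound 4 (0.15 log units; that floor lies within the scatter). Its true size cannot be read because the value for compound 3 is a limit: the limit of > 20000 nM in this assay, at which 2 of the 4 values shown sit. Changing the group on the nitrogen to tert-butyl gives a 1.4-fold higher number from compound 2 to compound 4 (0.16 log units; within the scatter), so benzyl and tert-butyl are not told apart here, and an at least 1.4-fold lower number from compound 1 to compound 4 (0.15 log units; that floor lies within the scatter).

The compounds shown leave open whether chloro, methoxy or an amine at that place would match fluoro. They also leave open what fluoro does with benzyl or phenyl on the nitrogen.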